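Hydroxycyclohexyl ureas: expectation for compound 4

The source may report more compounds than this note shows. Statements on the series, on what has been measured and on what is new or still open speak of the compounds shown alone.

Measured so far in a functional assay on the whole organism for inhibition, with Rattus norvegicus as the target, at a dose of 30 mg/kg by the oral route; a lower number here means less inhibition, a higher number more inhibition at the dose given (going by the name of the read-out):
compound 1, `CN(C(=O)NCCCOc1ccc2nc(O)ccc2c1)C1CCCCC1`: 15%
compound 2, `O=C(NCCCOc1ccc2nc(O)ccc2c1)N(C1CCCCC1)C1CC1`: 15%
compound 3, `CN(C(=O)NCCCOc1ccc2nc(O)ccc2c1)[C@@H]1CCCC[C@H]1O`: 10%

Compound 2 stands level with compound 1, the step of no change at the digits printed from compound 1 to compound 2 (within the scatter) showing no shift for cyclopropyl in place of methyl on an amide-type nitrogen. Compound 3 sits a few points lower, and the gap from compound 1 to compound 3, a number 5 percentage points lower from compound 1 to compound 3 (within the scatter), is within the scatter; all three numbers therefore sit in one band, and none of them can be set apart from the others as a higher or lower inhibition in this assay.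

Compound 4, `O=C(NCCCOc1ccc2nc(O)ccc2c1)N(C1CC1)[C@H]1CC[C@H](O)CC1`, differs from compound 2 by hydroxy in place of hydrogen on a saturated ring carbon. Going by the values given here, the one measured step that bears on it is the hydroxy-for-hydrogen change on a saturated ring carbon from compound 1 to compound 3, which gave a number 5 percentage points lower from compound 1 to compound 3 (within the scatter), a shift within the scatter. On that basis the same kind of change on compound 2 is expected to give no step beyond the scatter, so the estimated step of a number 2 percentage points lower from compound 2 to compound 4 (within the scatter) is essentially flat. Compound 4 is therefore expected to give about 13% in this assay, with a range from 3% to 25%.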

Compound 4, a percentage reported as inhibition, in the whole organism at one dose (the size of the read-out at that dose, not a potency): 7%
The estimate for compound 4 lay 6 percentage points above the measured number, within the range that was stated.
By their numbers in this assay, from the lowest: compounds 4, 3, 1 and 2 (each within the scatter of the next).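

Working notes on the hydroxy change: in this assay, cyclohexyl to 4-hydroxycyclohexyl, with the hydroxy three ring bonds from the ring atom that bears a large group, gives a number 8 percentage points lower from compound 2 to compound 4 (within the scatter). This extends the reading to a second core, with the cyclopropyl urea now carrying the change, and the two steps agree within the scatter: the same change on two cores in this assay, a number 5 percentage points lower (within the scatter) from compound 1 to compound 3 and a number 8 percentage points lower (within the scatter) from compound 2 to compound 4, 3 percentage points apart, within the scatter of two such steps Neither step leaves the scatter, so no gain or loss of inhibition in this assay can be assigned to hydroxy in place of hydrogen on either core, and no effect can be claimed for this position.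

Still open is whether an amine or a carboxylic acid on the same ring carbon would give a step beyond the scatter, since hydroxy is the only group shown entering there. With every reading taken at a single oral dose, the compounds shown also leave open whether the steps would stay within the scatter at another dose, as these numbers give the size of inhibition at that dose and not a potency.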